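The source may report more compounds than this note shows. Statements on the series, on what has been measured and on what is new or still open speak of the compounds shown alone.

Compound 1, `COC(=O)c1cccc(-c2cc(C(=O)Nc3ccncc3)ccc2CN)c1`, holds the lowest of the three numbers here: in an assay on isolated protein for inhibition of Rho-associated protein kinase 2 (Homo sapiens), read by radiometric assay (on this read-out higher numbers stand for weaker inhibition and lower numbers for stronger inhibition), compound 1 gives 2.9 nM. Compound 2, `NCc1ccc(C(=O)Nc2ccncc2F)cc1-c1cccc(C(=O)O)c1`, gives 55 nM in this assay, and compound 3, `NCc1ccc(C(=O)Nc2ccncc2F)cc1-c1cccc(C(=O)OC2CCCOC2)c1`, gives 8.7 nM. Among the measured compounds shown here, the only single-point step measured is a 6.3-fold lower number from compound 2 to compound 3 (0.80 log units; beyond the scatter). Compound 4, `NCc1ccc(C(=O)Nc2ccncc2)cc1-c1cccc(C(=O)OCC2CCCC2)c1`, is compound 1 carrying (cyclopentyl in place of hydrogen on a saturated chain carbon bound to an oxygen next to a carbonyl group). The step from compound 2 to compound 3 turns an acid into an ester rather than extending an ester already present, so it bears on this change only loosely; compound 1 and compound 3 differ in two places, yet both show that an ester beyond methyl stays strong. A step near zero, or small in either direction, is therefore expected, a 1.4-fold higher number from compound 1 to compound 4 (0.14 log units; within the scatter). Compound 4 is estimated at 4 nM, within a range from 1.5 nM to 12 nM.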

Compound 4, half-maximal inhibitory concentration: 5 nM
For compound 4 the middle estimate is 1.3-fold (0.10 log units) below the measured one, and the stated range covers the measured number.
By their numbers in this assay, from the lowest: compounds 1, 4 and 3 (each within the scatter of the next, the first and the last beyond it); then compound 2.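

In this assay, replacing methoxycarbonyl with cyclopentylmethoxycarbonyl gives a 1.7-fold higher number from compound 1 to compound 4 (0.24 log units; within the scatter), so cyclopentyl on this saturated chain carbon leaves the number within the scatter. This is the first step shown that changes the ester itself in one place, rather than turning an acid into an ester. Nothing at hand accounts for this result.

The compounds shown leave open how a phenyl ring in place of cyclopentyl would read here. They also leave open what an amine or a carboxylic acid carried on the ester chain, or a longer chain, would do.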